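Swapping a tetrazole for a methylpyrazole on a urea core

This account rests on a few compounds, and the source may have more. Where it says the series, first, only, none or still open, it means among the compounds named here.

Measured so far:
compound 1 `Cc1cc(C)c(NC(=O)N(Cc2cccc(-c3nn[nH]n3)c2)C2CCCCCC2)c(C)c1` gives > 1000 nM
compound 2 `CSc1cc(C)nc(SC)c1NC(=O)N(Cc1ccccc1)Cc1cccc(-c2ccnn2C)c1` gives 28 nM
compound 3 `Cc1cc(C)c(NC(=O)N(Cc2ccc(-c3cc[nH]n3)cc2)C2CCCCCC2)c(C)c1` gives 52 nM

The three compounds were tested in an assay on microsomes from intestine for inhibition of acyl-CoA:cholesterol acyltransferase (Oryctolagus cuniculus); a higher number here means a weaker inhibitor, a lower number a stronger inhibitor. Compound 1 stands at the limit of the assay, and its reported value of > 1000 nM is a limit rather than a number. Sharing the core of compound 1, compound 3 gives 52 nM in this assay. Compound 2, built on a different core, gives 28 nM in this assay. The weakest result shown is that of compound 1, of which it is only known that (the limit of > 1000 nM in this assay, at which 1 of the 3 values shown sits).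

The unmeasured compound 4 `Cc1cc(C)c(NC(=O)N(Cc2cccc(-c3cnn(C)c3)c2)C2CCCCCC2)c(C)c1` is obtained from compound 1 by 1-methyl-1H-pyrazol-4-yl in place of 2H-tetrazol-5-yl on an aromatic carbon, the change being 1-methyl-1H-pyrazol-4-yl in place of 2H-tetrazol-5-yl on an aromatic carbon. Among the measured compounds shown here, no pair of measured compounds differs in exactly this way. Since both measured compounds carrying a pyrazole, compound 3 with 52 nM and compound 2 with 28 nM, sit well inside the measurable range, compound 4 is expected to give a measurable value as well. The step from compound 1 to compound 4 is estimated at an at least 16-fold lower number from compound 1 to compound 4 (1.22 log units; beyond the scatter), toward stronger inhibition. Compound 4 is therefore estimated at 60 nM, within a range from 15 nM to 300 nM.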

Compound 4, half-maximal inhibitory concentration: 44 nM
Compound 4: middle estimate off by 1.4-fold (0.13 log units), on the high side, and the stated range covers the measured number.
By their numbers in this assay, from the lowest: compounds 2, 4 and 3 (each within the scatter of the next). At a limit, above all of these: compound 1.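

In this assay, the place on the six-membered aromatic ring, meta to a large group, accepts 1-methyl-1H-pyrazol-4-yl: putting it in place of 2H-tetrazol-5-yl on the shared core gives an at least 22-fold lower number from compound 1 to compound 4 (1.35 log units; beyond the scatter), a large step. This is the first change shown that can be read in one place, and it ties the drop in the number directly to the exchange of these two rings. For compound 1, the > 1000 nM is a limit and not a number, so the step has a bound rather than a size: the limit of > 1000 nM in this assay, at which 1 of the 4 values shown sits.

The single step changes the ring and adds the methyl group together, so the compounds shown do not separate the two. From the compounds shown here alone, how a carboxylic acid or a simple amine would fare at this same place also remains open.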